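Shortening an ethoxy to a methoxy on a quinoline amide

A few compounds are considered here, and "the series" means these few. Any claim that something is new, unique, unknown or untested is made for them only; others in the source may bear on it.

Two compounds have been measured in a functional assay on Hep 3B2 cells (Homo sapiens) for antiproliferative activity, read by MTT assay, with a stated time of 24 h, tested at 100 ug/mL; a lower number here means a weaker effect, a higher number a stronger effect of the compound at the concentration tested:
compound 1, `CCc1ccc2nc(C(=O)Nc3c(F)cc(-c4cccc(F)c4)cc3F)c(C)c(C(=O)O)c2c1`, gives 64.3%
compound 2, `CCOc1ccc2nc(C(=O)Nc3c(F)cc(-c4cccc(F)c4)cc3F)c(C)c(C(=O)O)c2c1`, gives 65.3%

Compound 2 stands alongside compound 1 rather than apart from it, since a number 1 percentage points higher from compound 1 to compound 2 (within the scatter). For the measured compounds named here, that step swaps the whole ethyl for an ethoxy and leaves the read-out essentially unchanged, so this is the only measured step that bears on the next one.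

Compound 3, `COc1ccc2nc(C(=O)Nc3c(F)cc(-c4cccc(F)c4)cc3F)c(C)c(C(=O)O)c2c1`, differs from compound 2 by hydrogen in place of methyl on a saturated chain carbon bound to an oxygen on an aromatic ring. A small trimming of the same chain, after a larger swap at this spot moved nothing, is expected to give a number 1.3 percentage points lower from compound 2 to compound 3 (within the scatter). Compound 3 is therefore estimated at 64%, with a range from 52% to 76%.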

Compound 3, a percentage reported as inhibition, at one concentration (the size of the read-out at that concentration, not a potency): 28.3%
Compound 3: middle estimate off by 35.7 percentage points, on the high side; the whole stated range lies above it.
By their numbers in this assay, from the lowest: compound 3; then compounds 1 and 2 (each within the scatter of the next).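

Trimming a single methyl from the ethoxy chain gives a number 37 percentage points lower from compound 2 to compound 3 (beyond the scatter) in this assay, so this position responds sharply to a change far smaller than the ethyl-to-ethoxy swap that moved nothing. Ethyl and ethoxy read alike here, yet methoxy does not join them, with a number 36 percentage points lower from compound 1 to compound 3 (beyond the scatter) on the same core. Nothing available explains why one carbon counts for so much.

The compounds shown leave open whether a propoxy or a longer chain would hold the read-out of compound 2, and whether a hydroxyl group at this spot would fall as low as compound 3.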